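The source may report more compounds than this note shows. Statements on the series, on what has been measured and on what is new or still open speak of the compounds shown alone.

Measured compounds in a functional assay on HepG2 cells (Homo sapiens) for cytotoxicity, read by MTT assay, with a stated time of 24 h; on this read-out lower numbers stand for stronger inhibition and higher numbers for weaker inhibition:
compound 1, `COc1cc(/C=C2\CN(C)C/C(=C\c3cccc([N+](=O)[O-])c3)C2=O)cc(OC)c1`, compound 1 gives 1840 nM;
compound 2, `COc1cc(/C=C2\CN(C)C/C(=C\c3ccc(C#N)cc3)C2=O)cc(OC)c1`, compound 2 gives 880 nM;
compound 3, `COc1cc(/C=C2\CN(C)C/C(=C\c3cccc([N+](=O)[O-])c3)C2=O)cc(OC)c1OC`, compound 3 gives 1890 nM.

Compound 4, `COc1cc(/C=C2\CN(C)C/C(=C\c3ccc(C#N)cc3)C2=O)cc(OC)c1OC`, is not yet measured. Compound 3 differs from compound 1 by methoxy in place of hydrogen on an aromatic carbon, a change that gave a 1.0-fold higher number from compound 1 to compound 3 (0.01 log units; within the scatter). Compound 2 differs from compound 1 by 4-cyanophenyl in place of 3-nitrophenyl on a double-bonded chain carbon bound to a double-bonded ring carbon, and that change gave a 2.1-fold lower number from compound 1 to compound 2 (0.32 log units; beyond the scatter). Compound 4 differs from compound 3 by 4-cyanophenyl in place of 3-nitrophenyl on a double-bonded chain carbon bound to a double-bonded ring carbon, the same change at the same place, now made on the core that carries the extra methoxy.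

For the measured compounds named here, only one example of this change is in hand, so the expectation rests on a single step. For compound 4 a step of a 2.1-fold lower number from compound 3 to compound 4 (0.32 log units; beyond the scatter) is expected, matching what compound 1 to compound 2 showed in this assay. Compound 4 is estimated at 900 nM, with a plausible range from 500 nM to 1700 nM.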

Compound 4, half-maximal inhibitory concentration: 1140 nM
Estimate against measurement, compound 4: 1.3-fold (0.10 log units) below; measured number inside the range.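

In this assay the change to 4-cyanophenyl on the core with the extra methoxy gives a 1.7-fold lower number from compound 3 to compound 4 (0.22 log units; within the scatter) and agrees with the step on the core of compound 1: the same change on two cores in this assay, a 2.1-fold lower number (0.32 log units; beyond the scatter) from compound 1 to compound 2 and a 1.7-fold lower number (0.22 log units; within the scatter) from compound 3 to compound 4, 1.3-fold (0.10 log units) apart, within the scatter of two such steps.

The added methoxy gives a 1.3-fold higher number from compound 2 to compound 4 (0.11 log units; within the scatter) and also carries across the two aryl groups without a detectable difference: the same change on two cores in this assay, a 1.0-fold higher number (0.01 log units; within the scatter) from compound 1 to compound 3 and a 1.3-fold higher number (0.11 log units; within the scatter) from compound 2 to compound 4, 1.3-fold (0.10 log units) apart, within the scatter of two such steps.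

This supports transfer between these two cores only; the step on the methoxy core does not by itself exceed the scatter, and a single pair of cores says nothing about others in the series.

The compounds shown carry only 3-nitrophenyl and 4-cyanophenyl at this place, so an aminophenyl or a carboxyphenyl there remains open. From the compounds shown here alone, a longer chain in place of the methyl on the nitrogen of the shared core also remains open.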